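The source may hold more compounds than are shown below. What is called first, only, known or untested is meant among the compounds shown, and "the series" means these compounds.

Of the compounds shown here, three have been measured in a functional assay on KM12 cells (Homo sapiens) for inhibition, read by sulforhodamine B assay, with a stated time of 48 h; on this read-out lower numbers stand for higher toxicity in this test and higher numbers for lower toxicity in this test: compound 1 `COc1ccc(-c2cc(/C=C/C(=O)c3ccc(N)cc3)[nH]n2)cc1` gives 7610 nM, compound 2 `COc1ccc(C(=O)/C=C/c2cc(-c3cc(OC)c(OC)c(OC)c3)n[nH]2)cc1OC` gives 5430 nM, and compound 3 `COc1ccc(-c2cc(/C=C/C(=O)c3ccc(N)cc3)[nH]n2)cc1OC` gives 6670 nM.

Compound 3 differs from compound 1 by methoxy in place of hydrogen on an aromatic carbon, and this change produced a 1.1-fold lower number from compound 1 to compound 3 (0.06 log units; within the scatter). Compound 2 and compound 1 are built on different cores; the difference between the two cores is not broken down here, and their two values show only that they sit close together.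

Compound 4 `COc1cc(C(=O)/C=C/c2cc(-c3cc(OC)c(OC)c(OC)c3)n[nH]2)cc(OC)c1OC` has not yet been measured. It differs from compound 2 by methoxy in place of hydrogen on an aromatic carbon. This is the same kind of change as that from compound 1 to compound 3, though the surroundings differ: in compound 4 the entering methoxy is also meta to a methoxy group, which is not so in compound 3. Because a 1.1-fold lower number from compound 1 to compound 3 (0.06 log units; within the scatter) stayed within the scatter, compound 4 is expected to show a 1.1-fold lower number from compound 2 to compound 4 (0.04 log units; within the scatter) in this assay. The estimate for compound 4 is 5000 nM, expected to lie between 2200 nM and 11500 nM.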

Compound 4, concentration lethal to 50% of the cells: 5770 nM
Compound 4: the middle estimate sits 1.2-fold (0.06 log units) below what was measured, and the stated range covers the measured number.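

In this assay, methoxy in place of hydrogen on an aromatic carbon gave a 1.1-fold higher number from compound 2 to compound 4 (0.03 log units; within the scatter). Set beside the earlier step, the change reads alike on the two cores: the same change on two cores in this assay, a 1.1-fold lower number (0.06 log units; within the scatter) from compound 1 to compound 3 and a 1.1-fold higher number (0.03 log units; within the scatter) from compound 2 to compound 4, 1.2-fold (0.08 log units) apart, within the scatter of two such steps

This shows that, across these two pairs, the change carried from one core to the other without a step beyond the scatter; it does not show that it would do the same on a further core, at another place on the ring or in another assay, and two small steps give no measure of how the change behaves where it has a larger effect.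

The aromatic rings shown carry only methoxy groups and, in compound 1 and compound 3, an amine, so it stays open how a hydroxyl, an ethoxy or a chlorine would read in this assay in place of the entering methoxy. Whether a carboxylic acid in place of the amine of compound 3 would give a step beyond the scatter is open as well.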